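A few compounds are considered here, and "the series" means these few. Any claim that something is new, unique, unknown or untested is made for them only; others in the source may bear on it.

Measured so far:
- compound 1, `CC(C)C/C=C1\CC(CO)(COC(=O)CC(C(C)C)C(C)C)OC1=O`: 4.1
- compound 2, `CC(C)C(CC(=O)OC[C@H](CO)OC(=O)CC(C(C)C)C(C)C)C(C)C`: 5.8

Within the data shown here, compound 2 holds the higher of the two numbers in a physicochemical assay for lipophilicity; a lower number here means a more polar compound, a higher number a more lipophilic compound; the only neighbour is compound 1, which lies lower by a gap beyond the scatter. Compound 3, `CC(C)=CC(=O)O[C@@H](CO)COC(=O)CC(C(C)C)C(C)C`, has not been run in this assay yet.

The change from compound 2 to compound 3 is 2-methylprop-1-en-1-yl in place of 2-isopropyl-3-methylbutyl on a carbonyl carbon. The leaving group carries more heavy atoms than the entering one, all carbon in both cases, with no donor or acceptor added or lost and no charge involved. Among the measured compounds shown here, no step between measured compounds is known for this kind of exchange, so the size rests on the count alone.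

For compound 3 a drop in this assay is expected, with an estimated step of a number 1.80 log units lower from compound 2 to compound 3 (beyond the scatter). Compound 3 is estimated at 4, within 3.4 to 4.6.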

Compound 3, partition coefficient: 3.9
Compound 3: the middle estimate sits 0.10 log units above what was measured, and the stated range covers the measured number.
By their numbers in this assay, from the lowest: compounds 3 and 1 (each within the scatter of the next); then compound 2.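

In this assay, among these compounds, 2-methylprop-1-en-1-yl in place of 2-isopropyl-3-methylbutyl on a carbonyl carbon gives a number 1.90 log units lower from compound 2 to compound 3 (beyond the scatter), the first step that can be read at a single place. The number at this position therefore responds strongly to this exchange, which lowers the heavy-atom count and brings in a double bond outside aromatic rings, both in the same step. No measurement bears on the origin of the step, so it stands as an observation only.

With one step, the share of the shorter carbon count and the share of the double bond cannot be separated, and a saturated 2-methylpropyl group at the same place would bear on that question. As far as these compounds go, how a carboxylic acid or an amine on this chain would move the number also stays open.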